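A Ring Swap on the Shared Core of Compound 1

This account rests on a few compounds, and the source may have more. Where it says the series, first, only, none or still open, it means among the compounds named here.

Compound 1, `COc1ccc(C2=NN(C3=NC(c4ccccc4)CS3)C(c3cccc4ccccc34)C2)cc1`, gives 3310 nM in a functional assay on HeLa cells (Homo sapiens) for inhibition, read by CCK-8 assay, with a stated time of 48 h; a higher number here means a weaker inhibitor, a lower number a stronger inhibitor.
Compound 2, `Cc1ccc(C2=NN(C3=NC(c4ccccc4)CS3)C(c3cccc4ccccc34)C2)cc1C`, gives 1720 nM in this assay.
Compound 3, `Cc1ccc(C2=NN(C3=NC(c4ccccc4)CS3)C(c3cccc4ccccc34)C2)cc1`, gives 4290 nM in this assay.

Among these three numbers compound 1 stands second highest. Its nearest neighbour is compound 3, its furthest compound 2, and both of those gaps fall within the scatter: a 1.3-fold higher number from compound 1 to compound 3 (0.11 log units; within the scatter) and a 1.9-fold lower number from compound 1 to compound 2 (0.28 log units; within the scatter). Within the data shown here, the only step that reaches beyond the scatter is a 2.5-fold higher number from compound 2 to compound 3 (0.40 log units; beyond the scatter), and it is modest. All three steps concern the substituted aromatic ring on the shared core and nothing else.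

Compound 4, `COc1ccc(C2=NN(C3=NC(=O)CS3)C(c3cccc4ccccc34)C2)cc1`, is a different matter. Its change from compound 1 is a group of 6 heavy atoms (3 carbon, 1 nitrogen, 1 oxygen, 1 sulfur; one five-membered non-aromatic ring with 2 hetero atoms) in place of a group of 11 heavy atoms (9 carbon, 1 nitrogen, 1 sulfur; one five-membered non-aromatic ring with 2 hetero atoms, one six-membered aromatic ring of carbon only), on an amine nitrogen in a ring. Among the measured compounds shown here, no measured step touches this part of the core, so none of the three bears on it directly. For the measured compounds named here, what the measured steps do show is that the numbers in this assay have so far moved only modestly, and an exchange of this size on an untested part of the molecule has no precedent here. The estimate for compound 4 is therefore placed near compound 1 with a wide range, as 5000 nM (1500 nM to 20000 nM), which corresponds to an expected step of a 1.5-fold higher number from compound 1 to compound 4 (0.18 log units; within the scatter).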

Compound 4, half-maximal inhibitory concentration: 2540 nM
The estimate for compound 4 lay 2.0-fold (0.29 log units) above the measured number; low and high end bracket the measured number.
By their numbers in this assay, from the lowest: compounds 2, 4, 1 and 3 (each within the scatter of the next, the first and the last beyond it).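

In this assay, the exchange on the amine nitrogen in a ring, the only change shown at this part of the shared core, gives a 1.3-fold lower number from compound 1 to compound 4 (0.11 log units; within the scatter). A group of 6 heavy atoms can therefore stand in place of a group of 11 heavy atoms, losing the six-membered aromatic ring of carbon only and gaining a carbonyl, without a step beyond the scatter, something compounds 1, 2 and 3 could not show, as they differ only on the substituted aromatic ring. No measurement on hand accounts for this result.

Going by these compounds, with a single exchange at this nitrogen, it remains open whether the number would move beyond the scatter with an amine or a carboxylic acid on the five-membered non-aromatic ring of the entering group, or with a longer chain there in place of the carbonyl. On these data alone, it is also open whether the same exchange would give a similar step on compound 2, which carries 3,4-dimethylphenyl in place of the 4-methoxyphenyl group of compound 4.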